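The compounds below may be only part of what the source reports. "The series", "measured", "known", "first", "only" and "open" are said of these compounds alone.

Compound 1 `COc1cc(/C=C/C(=O)C2=C(/C=C/c3ccc(O)c(OC)c3)NC(=O)NC2c2c(Cl)cccc2Cl)ccc1O` gives 44.2% in a functional assay, with a stated time of 20 min, tested at 50 uM; a lower number here means a weaker effect, a higher number a stronger effect of the compound at the concentration tested. Compound 2 `COc1cc(/C=C/C(=O)C2=C(/C=C/c3ccc(O)c(OC)c3)NC(=O)NC2c2cccc([N+](=O)[O-])c2)ccc1O` gives 48% in this assay, and compound 3 `COc1cc(/C=C/C(=O)C2=C(/C=C/c3ccc(O)c(OC)c3)NC(=S)NC2c2ccc(C)cc2)ccc1O` gives 41% in this assay. Compound 3 has the lowest of the three numbers, yet its gaps to compound 1 and to compound 2 are both within the scatter, so no ordering among the three can be claimed.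

Compound 4 `COc1cc(/C=C/C(=O)C2=C(/C=C/c3ccc(O)c(OC)c3)NC(=S)NC2c2c(Cl)cccc2Cl)ccc1O` is not yet measured in this assay. It differs from compound 3 in one place: 2,6-dichlorophenyl in place of 4-methylphenyl on a saturated ring carbon. Within the data shown here, compound 1 and compound 4 share the 2,6-dichlorophenyl group, but compound 1 carries the urea and compound 4 the thiourea, and no step between them has been measured, so only the value of compound 1 can be noted beside compound 4.

Among the measured compounds shown here, the one measured step on the same saturated ring carbon, a number 3.8 percentage points higher from compound 1 to compound 2 (within the scatter), exchanges one aryl group for another and stays within the scatter. The expectation for compound 4 is therefore a step of about a number 2 percentage points higher from compound 3 to compound 4 (within the scatter), no larger than the scatter. Compound 4 is estimated at 43%, between 30% and 56%, in this assay.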

Compound 4, a percentage reported as activity, at one concentration (the size of the read-out at that concentration, not a potency): 50%
Compound 4: the middle estimate sits 7 percentage points below what was measured; the range from low to high includes it.
By their numbers in this assay, from the lowest: compounds 3, 1, 2 and 4 (each within the scatter of the next).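

With the thiourea in place, 2,6-dichlorophenyl in place of 4-methylphenyl on the saturated ring carbon gives a number 9 percentage points higher from compound 3 to compound 4 (within the scatter) in this assay, so the aryl exchange at this position now has a reading in the thiourea compounds as well as the urea compounds. Alongside a number 3.8 percentage points higher from compound 1 to compound 2 (within the scatter), this makes two aryl exchanges at this carbon, and neither step goes beyond the scatter. No supporting data bear on this step.

On these data alone, whether the urea and the thiourea differ while the aryl group stays the same remains open, as no such step can be read from these compounds. Also open, as far as these compounds go, is how this carbon responds to a group other than a substituted phenyl, such as a carboxylic acid, an amine or a longer alkyl chain.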